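A few compounds are considered here, and "the series" means these few. Any claim that something is new, unique, unknown or untested is made for them only; others in the source may bear on it.

In a physicochemical assay for lipophilicity, measured as octanol-water partition (a higher number here means a more lipophilic compound, a lower number a more polar compound), three compounds that share one core have been measured. Compound 1 (`CC1=C(C(=O)OCc2ccccn2)C(c2cccc(O)c2)C2=C(CCCC2=O)N1`) gives 1.58 and compound 2 (`CC1=C(C(=O)OCc2ccccn2)C(c2ccco2)C2=C(CCCC2=O)N1`) gives 1.4 while compound 3 (`COc1ccc(C2C(C(=O)OCc3ccccn3)=C(C)NC3=C2C(=O)CCC3)cc1`) stands highest of the three at 1.9 on this scale. Compound 4 (`CC1=C(C(=O)OCc2ccccn2)C(c2ccccc2[N+](=O)[O-])C2=C(CCCC2=O)N1`) differs from compound 3 in one place (2-nitrophenyl in place of 4-methoxyphenyl on a saturated ring carbon) with 2-nitrophenyl in place of 4-methoxyphenyl on a saturated ring carbon.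

Exchanges of groups at this same carbon offer the only guide. They gave a number 0.32 log units higher from compound 1 to compound 3 (beyond the scatter) and a number 0.50 log units higher from compound 2 to compound 3 (beyond the scatter) as well as a number 0.18 log units lower from compound 1 to compound 2 (within the scatter) so every measured step here has been small to modest. Among the measured compounds shown here, none of the measured compounds carries a 2-nitrophenyl group, so this guide is indirect. With compound 3 at the top of the measured values, a small move down seems likelier than a further rise. The expected change in this assay is a number 0.10 log units lower from compound 3 to compound 4 (within the scatter) and a larger move remains possible. For compound 4 the estimated value is 1.8 with an expected range from 1.4 to 2.2 once measured.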

Compound 4, partition coefficient: 1.88
The estimate for compound 4 lay 0.08 log units below the measured number; the measured number falls inside the stated range.
By their numbers in this assay, from the lowest: compounds 2, 1, 4 and 3 (each within the scatter of the next, the first and the last beyond it).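

In this assay, putting 2-nitrophenyl in place of 4-methoxyphenyl on this saturated ring carbon gives a number 0.02 log units lower from compound 3 to compound 4 (within the scatter) and so leaves the reading unresolved, even though the two groups differ in their atoms and hydrogen-bond acceptors. The same group gives a number 0.48 log units higher from compound 2 to compound 4 (beyond the scatter) when it replaces furan-2-yl and a number 0.30 log units higher from compound 1 to compound 4 (within the scatter) when it replaces 3-hydroxyphenyl, which places compound 4 within the scatter of both compound 1 and compound 3, although those two stand apart beyond it. Nothing available explains these numbers.

Going by these compounds, all four groups at this carbon are ring groups, so the effect of an amine, a carboxylic acid or a longer chain there remains open. Also open, on these data alone, is whether 4-nitrophenyl or 2-methoxyphenyl would read the same, since the nitro and methoxy groups are each seen at one ring position only.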